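Fluoro to methoxy on the fused ring: compound 3

The source may report more compounds than this note shows. Statements on the series, on what has been measured and on what is new or still open speak of the compounds shown alone.

Measured so far:
compound 1 `Cc1ccc(-c2ccc(F)cc2)n1-c1ccc(-c2nc3ccc(F)cc3s2)cc1` gives 1790 nM
compound 2 `Cc1ccc(-c2ccc([N+](=O)[O-])cc2)n1-c1ccc(-c2nc3ccc(F)cc3s2)cc1` gives 918 nM

In a functional assay on MCF7 cells (Homo sapiens) for cytotoxicity, read by sulforhodamine B assay, with a stated time of 48 h (on this read-out lower numbers stand for stronger inhibition of growth and higher numbers for weaker inhibition of growth), compound 2 stands at the lower of the two numbers, with compound 1 nearest; the step of a 1.9-fold lower number from compound 1 to compound 2 (0.29 log units; within the scatter) is within the scatter, so the two are not separated. Compound 3 `COc1ccc2nc(-c3ccc(-n4c(C)ccc4-c4ccc([N+](=O)[O-])cc4)cc3)sc2c1` differs from compound 2 by methoxy in place of fluoro on an aromatic carbon, on an aromatic carbon of a six-membered aromatic ring of carbon only, part of a fused or bridged system of two rings, meta to a fused ring and para to a fused ring. Among the compounds with values here, the only measured step, a 1.9-fold lower number from compound 1 to compound 2 (0.29 log units; within the scatter), concerns the other ring and does not bear on this change; no measured step touches the fused system. With nothing to carry over, the expected step of a 1.1-fold higher number from compound 2 to compound 3 (0.04 log units; within the scatter) is none beyond the scatter. Compound 3 is estimated at 1000 nM, range 300 nM to 3500 nM, in this assay.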

Compound 3, concentration for 50% growth inhibition: 3170 nM
Compound 3: the middle estimate sits 3.2-fold (0.50 log units) below what was measured; the measured number falls inside the stated range.
By their numbers in this assay, from the lowest: compounds 2, 1 and 3 (each within the scatter of the next, the first and the last beyond it).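

In this assay, methoxy in place of fluoro on the fused system gives a 3.5-fold higher number from compound 2 to compound 3 (0.54 log units; beyond the scatter) and so separates two compounds beyond the scatter, which the earlier change on the other ring, a 1.9-fold lower number from compound 1 to compound 2 (0.29 log units; within the scatter), did not do. This position on the six-membered aromatic ring of carbon only is therefore not indifferent to what it carries, and of the two groups seen here, fluoro goes with the lower number. Nothing measured on hand explains the step.

The compounds shown leave open whether a chlorine atom, a hydroxyl or an amine at this position would fall with fluoro or with methoxy. They also leave open whether the step from fluoro to methoxy keeps its size when the other ring carries fluoro, as in compound 1, rather than nitro.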